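Trading trifluoromethyl for hydrogen on a shared core

A few compounds are considered here, and "the series" means these few. Any claim that something is new, unique, unknown or untested is made for them only; others in the source may bear on it.

Of the compounds shown here, two built on one core have been tested in a functional assay on HL-60 cells (Homo sapiens) for cytotoxicity, read by CCK-8 assay, with a stated time of 24 h; on this read-out higher numbers stand for weaker inhibition and lower numbers for stronger inhibition. Compound 1 (`C=CC(=O)N1C(=O)CC(c2ccc(OC)cc2)Sc2ccccc21`) gives 92100 nM, and compound 2 (`C=CC(=O)N1C(=O)CC(c2ccccc2C(F)(F)F)Sc2ccccc21`) gives 96400 nM. These two numbers lie within the usual scatter of each other, so compound 2 stands level with compound 1. The next compound, compound 3 (`C=CC(=O)N1C(=O)CC(c2ccccc2)Sc2ccccc21`), has hydrogen in place of trifluoromethyl on an aromatic carbon. Among the measured compounds shown here, no measured pair yet isolates a single change, so the evidence is thin. Still, the aromatic ring carries different groups in compound 1, at 92100 nM, and in compound 2, at 96400 nM, and the numbers agree, which suggests little sensitivity here. Expected here is a 1.1-fold lower number from compound 2 to compound 3 (0.05 log units; within the scatter), which stays within the scatter and has no clear direction. For compound 3 the estimated value is 85000 nM, with an expected range of 40000 nM to 170000 nM.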

Compound 3, half-maximal inhibitory concentration: 97400 nM
Beside the measured number, compound 3's estimate is 1.1-fold (0.06 log units) below it; measured number inside the range.
By their numbers in this assay, from the lowest: compounds 1, 2 and 3 (each within the scatter of the next).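

In this assay, hydrogen in place of trifluoromethyl on an aromatic carbon gives a 1.0-fold higher number from compound 2 to compound 3 (0.00 log units; within the scatter), and hydrogen in place of methoxy on an aromatic carbon gives a 1.1-fold higher number from compound 1 to compound 3 (0.02 log units; within the scatter). Among the compounds shown here, these are the first comparisons that isolate a single change, and they show that compound 3, which carries neither group, stands level with both compound 1 and compound 2, so neither group makes a detectable difference to the number in this assay. No measurement shown here offers an explanation for this flat result.

From the compounds shown here alone, whether an amine or a carboxylic acid on this aromatic ring would move the number remains open. So does whether a change elsewhere on the shared core would matter more than these swaps on the ring.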